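The compounds below may be only part of what the source reports. "The series", "measured", "known", "first", "only" and "open" are said of these compounds alone.

Three compounds built on one shared core have been run through a functional assay on the whole organism (artery, strain albino) with Rattus norvegicus as the target, with a stated time of 15 min, at a dose of 10 mg/kg by the oral route; a higher number here means more inhibition at the dose given (going by the name of the read-out), a lower number less inhibition. Compound 1 `CC1=C(C(=O)Nc2ccc(Br)cc2)C(c2ccc(Cl)cc2Cl)N=C(SCc2ccc(Cl)cc2)N1` gives 4.1%, compound 2 `COc1ccc(C2N=C(SCc3ccc(F)cc3)NC(C)=C2C(=O)Nc2ccc(Br)cc2)cc1` gives 3.6%, and compound 3 `CC1=C(C(=O)Nc2ccc([N+](=O)[O-])cc2)C(c2ccc(Br)cc2)N=C(SCc2ccccc2)N1` gives 2.1%. Compound 3 holds the lowest of these three numbers, yet all three sit within the usual scatter of one another, so no order can be read among them. Compound 4 `CC1=C(C(=O)Nc2ccc([N+](=O)[O-])cc2)C(c2ccc(Br)cc2)N=C(SCc2ccc(Cl)cc2)N1` has not been measured; it differs from compound 3 by chloro in place of hydrogen on an aromatic carbon. For the measured compounds named here, no measured pair shows what such a change does here, so nothing beyond the scatter is anticipated. The step of a number 1.4 percentage points higher from compound 3 to compound 4 (within the scatter) is expected to stay within the scatter. Compound 4 is expected to give 3.5% in this assay, between 0% and 12%.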

Compound 4, a percentage reported as inhibition, in the whole organism at one dose (the size of the read-out at that dose, not a potency): 3.1%
Compound 4: the middle estimate sits 0.4 percentage points above what was measured, within the range that was stated.
By their numbers in this assay, from the lowest: compounds 3, 4, 2 and 1 (each within the scatter of the next).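

For the compounds shown here, compound 3 and compound 4 form the first pair here that differs in only one place, benzylsulfanyl to (4-chlorobenzyl)sulfanyl. In this assay this exchange of hydrogen for chloro gives a number 1 percentage points higher from compound 3 to compound 4 (within the scatter), so a single chloro at this position has no readable effect on the result. No measured information on the compounds bears on this result.

On these data alone, whether an amine or a carboxylic acid at this position would move the number beyond the scatter remains open. So does whether chloro would behave the same way on a different core substitution pattern.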